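The compounds below may be only part of what the source reports. "The series", "measured", "known", "first", "only" and "open" are said of these compounds alone.

The series shares the core of compound 1 `C=CCn1c(=O)/c(=C\c2cccc(C)c2)[nH]c(=O)/c1=C\c1ccccc1OC`, which in a functional assay on K562 cells (Homo sapiens) for cytotoxicity, read by CCK-8 assay, with a stated time of 72 h (on this read-out lower numbers stand for stronger inhibition and higher numbers for weaker inhibition), gives 8800 nM. Compound 2 `C=CCn1c(=O)/c(=C\c2cccc(F)c2)[nH]c(=O)/c1=C\c1ccccc1OC` gives 4100 nM in this assay, and compound 3 `C=CCn1c(=O)/c(=C\c2cc(F)ccc2C)[nH]c(=O)/c1=C\c1ccccc1OC` gives 1800 nM. Compound 2 therefore stands second highest of the three numbers, separated from compound 1 by a 2.1-fold lower number from compound 1 to compound 2 (0.33 log units; beyond the scatter) and from compound 3 by a 2.3-fold lower number from compound 2 to compound 3 (0.36 log units; beyond the scatter).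

Compound 4 `C=CCn1c(=O)/c(=C\c2cccc(Cl)c2)[nH]c(=O)/c1=C\c1ccccc1OC` differs from compound 2 by chloro in place of fluoro on an aromatic carbon. The step that bears on this change is the one that touched the same aromatic carbon, from compound 1 to compound 2, where fluoro in place of methyl gave a 2.1-fold lower number from compound 1 to compound 2 (0.33 log units; beyond the scatter), a modest step beyond the scatter. The step from compound 2 to compound 3, a 2.3-fold lower number from compound 2 to compound 3 (0.36 log units; beyond the scatter), concerns a different carbon and says little about a halogen swap. Among the measured compounds shown here, no measured pair exchanges fluoro for chloro, so the direction of the step from compound 2 to compound 4 in this assay cannot be read from the three numbers; a step within the scatter, or a modest one in either direction, seems most likely.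

The estimate for compound 4 in this assay is 4000 nM, with a range from 1800 nM to 9000 nM, which means an expected step of a 1.0-fold lower number from compound 2 to compound 4 (0.01 log units; within the scatter).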

Compound 4, half-maximal inhibitory concentration: 2700 nM
For compound 4 the middle estimate is 1.5-fold (0.17 log units) above the measured one; the range from low to high includes it.
By their numbers in this assay, from the lowest: compounds 3, 4 and 2 (each within the scatter of the next, the first and the last beyond it); then compound 1.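

At this aromatic carbon, meta to a large group, the exchange of halogens gives a 1.5-fold lower number from compound 2 to compound 4 (0.18 log units; within the scatter) in this assay, so fluoro and chloro cannot be told apart here. Methyl is the group that stands apart among the three at this carbon: fluoro in its place gives a 2.1-fold lower number from compound 1 to compound 2 (0.33 log units; beyond the scatter), and chloro in its place gives a 3.3-fold lower number from compound 1 to compound 4 (0.51 log units; beyond the scatter). The 3-chlorophenyl group in place of 5-fluoro-2-methylphenyl gives a 1.5-fold higher number from compound 3 to compound 4 (0.18 log units; within the scatter), so compound 4 lies within the scatter of both compound 2 and compound 3, even though those two are separated by a step beyond the scatter.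

Nothing available on these compounds offers an explanation for these numbers. Left open is how an amine, a carboxylic acid or a trifluoromethyl group would behave at this same carbon, and whether the added methyl that separates compound 3 from compound 2 would give a comparable step on the ring of compound 4, where chloro takes the place of fluoro.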